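The source may report more compounds than this note shows. Statements on the series, on what has been measured and on what is new or still open speak of the compounds shown alone.

Series notes. The core shared by all compounds here carries a sulfonyl-linked aryl group and an aminomethyl-type substituent on the saturated ring. Within the data shown here, in an assay on isolated protein for displacement of a labelled ligand from 5-hydroxytryptamine receptor 6 (Homo sapiens) (a higher number here means a weaker inhibitor, a lower number a stronger inhibitor), compound 1 `NC[C@@H]1CCCc2cc(S(=O)(=O)c3cccc(O)c3)ccc21` gives 0.251 nM, and compound 2 `NC[C@@H]1CCCc2cc(S(=O)(=O)c3cc[nH]c3)ccc21` gives 0.316 nM; the only step measured between two compounds differing in one place, a 1.3-fold higher number from compound 1 to compound 2 (0.10 log units; within the scatter), concerns the sulfonyl aryl group and not the chain substituent. Compound 3 `O=C1CN(C[C@@H]2CCCc3cc(S(=O)(=O)c4cccc(F)c4)ccc32)CCN1` gives 6.31 nM in this assay, the highest of the three numbers; its nearest neighbour is compound 2 and its furthest compound 1, both of them beyond the scatter, and both carrying a primary aminomethyl group where compound 3 carries the 3-oxopiperazin-1-yl group.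

Compound 4 `CC(=O)N(C)C[C@@H]1CCCc2cc(S(=O)(=O)c3cccc(F)c3)ccc21` is not yet measured. Its change from compound 3 is acetyl(methyl)amino in place of 3-oxopiperazin-1-yl on a saturated chain carbon bound to a saturated ring carbon. Among the measured compounds shown here, no measured step addresses this position directly; compounds 1 and 2 differ from compound 3 at the sulfonyl aryl as well, so their numbers give only an indirect reading. With an acetyl(methyl)amino group in place of the 3-oxopiperazin-1-yl group, a somewhat higher number than that of compound 3 is expected in this assay, roughly a 4.8-fold higher number from compound 3 to compound 4 (0.68 log units; beyond the scatter). For compound 4 the estimate in this assay is 30 nM, with a range from 5 nM to 200 nM.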

Compound 4, inhibition constant: 1.59 nM
Compound 4: middle estimate off by 19-fold (1.28 log units), on the high side, and the stated range ends above it.
By their numbers in this assay, from the lowest: compounds 1 and 2 (each within the scatter of the next); then compound 4; then compound 3.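

Among these compounds, with the sulfonyl aryl group held fixed, the step in this assay (a 4.0-fold lower number from compound 3 to compound 4 (0.60 log units; beyond the scatter)) gives the first direct reading at the saturated chain carbon bound to a saturated ring carbon, and it shows that this position responds to the choice of substituent. The six-membered ring of the 3-oxopiperazin-1-yl group and its hydrogen-bond donor are not required for a low number here, since compound 4, whose acetyl(methyl)amino group has no ring and no hydrogen-bond donor, gives 1.59 nM in this assay. No data of any other kind bear on this step, and the loss of the ring, the smaller group and the changed hydrogen-bond counts cannot be separated from one another on this single pair.

As far as these compounds go, whether a primary amine, a dimethylamino group or an unsubstituted piperazin-1-yl group on this chain carbon would give a lower or higher number with the sulfonyl aryl group of compound 3 and compound 4 remains open. Compound 1 and compound 2 differ from compound 4 in two places, so the share of the chain substituent in those gaps cannot be read.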